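Cytotoxicity notes: the step from compound 1 to compound 3

This account rests on a few compounds, and the source may have more. Where it says the series, first, only, none or still open, it means among the compounds named here.

In an ADME assay on HOS cells (Homo sapiens) for cytotoxicity, read by luminescence and ATP content, with a stated time of 48 h (a higher number here means that more compound is tolerated, a lower number that less compound is tolerated), compound 1 (`O=C(NCc1ccc(F)cc1F)c1c(O)c2cc(CCCCCO)cnc2n(O)c1=O`) gives > 250000 nM, which is a limit and not a number. Compound 2 (`CC(C)NC(=O)CCc1cnc2c(c1)c(N)c(C(=O)NCc1ccc(F)cc1F)c(=O)n2O`) gives > 250000 nM, also a limit. Neither compound has a measured concentration, and the evidence so far amounts to the limit of > 250000 nM in this assay, at which 2 of the 2 values shown sit.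

Compound 3 (`COC(=O)CNc1c(C(=O)NCc2ccc(F)cc2F)c(=O)n(O)c2ncc(CCCCCO)cc12`) carries ((methoxycarbonyl)methyl)amino in place of hydroxy on an aromatic carbon of the core of compound 1, opposite the ring nitrogen: ((methoxycarbonyl)methyl)amino in place of hydroxy on an aromatic carbon.

Within the data shown here, no measured step covers this change, so what follows is expectation only. In this assay, the most likely outcome is no step beyond the scatter, with a modest move towards less compound tolerated as the alternative. A limit reading for compound 3 is expected to be slightly more likely than a number. The estimated step is an at least 1.2-fold lower number from compound 1 to compound 3 (0.09 log units; that floor lies within the scatter). For compound 3 the estimated half-maximal cytotoxic concentration is 200000 nM, with an expected range from 40000 nM to 250000 nM.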

Compound 3, half-maximal cytotoxic concentration: > 250000 nM
Compound 3 was reported as a limit (the forecaster's own chance of this, stated with the estimate: 55%); at least 1.2-fold (0.09 log units) between middle value and limit.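

Compound 3, like compound 1, reads as a limit and not a number in this assay, so no step can be read between compound 1 and compound 3. The compounds shown leave open at what concentration any of them becomes cytotoxic, and whether ((methoxycarbonyl)methyl)amino in place of hydroxy shifts that concentration at all: the limit of > 250000 nM in this assay, at which 3 of the 3 values shown sit.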